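Hydroxy for dimethylamino on a weakly binding series

This account rests on a few compounds, and the source may have more. Where it says the series, first, only, none or still open, it means among the compounds named here.

The measured compounds in an assay on NK92 cells for inhibition of interleukin-15 (Homo sapiens), read by AlphaScreen, with stated times of 30 min and 1 h (on this read-out lower numbers stand for stronger inhibition and higher numbers for weaker inhibition), are:
compound 1 `Cn1c(Cc2nn(CCCO)c(=O)c3ccccc23)nnc1SCC(=O)Nc1ccc(Cl)cc1Cl` with 30000 nM.
compound 2 `CN(C)CCCn1nc(Cc2nnc(SCC(=O)Nc3ccc(Cl)cc3Cl)n2C)c2ccccc2c1=O` with > 30000 nM, which is a limit of the assay and not a number.
compound 3 `CN(C)CCCn1nc(Cc2nnc(SCCCCCCCC(=O)Nc3ccc(Cl)cc3Cl)n2C)c2ccccc2c1=O` with > 30000 nM, also a limit of the assay and not a number.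

Compound 1 arises from compound 2 by the change (hydroxy in place of dimethylamino on a saturated chain carbon, three bonds along the chain from an aromatic nitrogen). The step it made is a number no higher from compound 2 to compound 1 (the limit leaves the size open); with the limit of > 30000 nM in this assay, at which 2 of the 3 values shown sit, its true size cannot be read. Compound 4 `Cn1c(Cc2nn(CCCO)c(=O)c3ccccc23)nnc1SCCCCCCCC(=O)Nc1ccc(Cl)cc1Cl` arises from compound 3 by hydroxy in place of dimethylamino on a saturated chain carbon, three bonds along the chain from an aromatic nitrogen, at a place described in the same words, so this is the same change. The difference between the cores of compound 2 and compound 3 is not broken down here. From compound 3 to compound 4 a step of a number no higher from compound 3 to compound 4 (the limit leaves the size open) is expected, resting on a number no higher from compound 2 to compound 1 (the limit leaves the size open) and on (the limit of > 30000 nM in this assay, at which 2 of the 3 values shown sit). The expected value of compound 4 is 30000 nM, between 12000 nM and 80000 nM, with a good chance that this assay again reports only a limit.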

Compound 4, half-maximal inhibitory concentration: > 30000 nM
Compound 4 gave a limit, no number; the forecaster's own chance of this, stated with the estimate: 65%; the middle value lies on the limit itself.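

No step can be read from compound 3 to compound 4, since each gave only a limit of the assay and no number: the limit of > 30000 nM in this assay, at which 3 of the 4 values shown sit. The compounds shown leave open how much hydroxy in place of dimethylamino really changes inhibition.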